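From acid to hydroxyethyl amide: predicting compound 4

This account rests on a few compounds, and the source may have more. Where it says the series, first, only, none or still open, it means among the compounds named here.

Measured in a functional assay on LNCaP cells (Homo sapiens) for antiproliferative activity; on this read-out lower numbers stand for stronger inhibition and higher numbers for weaker inhibition:
- compound 1 `Cn1ncc(Cl)c1-c1cc(C(=O)N[C@@H]2CN[C@H](CCNS(C)(=O)=O)C[C@H]2c2ccc(F)c(F)c2)oc1Cl`: 50 nM
- compound 2 `Cn1ncc(Cl)c1-c1cc(C(=O)N[C@@H]2CN[C@H](CC(=O)O)C[C@H]2c2ccc(Cl)c(Cl)c2)oc1Cl`: 640 nM
- compound 3 `CNC(=O)C[C@@H]1C[C@@H](c2ccc(F)c(F)c2)[C@H](NC(=O)c2cc(-c3c(Cl)cnn3C)c(Cl)o2)CN1`: 50 nM

Compound 2 has the highest number of the three, which means the weakest inhibition, and it lies well beyond the scatter from both neighbours. It is also the only one of the three that carries a carboxy group.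

Compound 4 `Cn1ncc(Cl)c1-c1cc(C(=O)N[C@@H]2CN[C@H](CC(=O)NCCO)C[C@H]2c2ccc(Cl)c(Cl)c2)oc1Cl` keeps the rest of compound 2 and changes one place: (2-hydroxyethyl)amino in place of hydroxy on a carbonyl carbon. In words, (2-hydroxyethyl)amino stands in place of hydroxy on a carbonyl carbon, so carboxy becomes (2-hydroxyethyl)carbamoyl.

Among the compounds with values here, no measured pair isolates this change. The nearest single-place evidence is no change at the digits printed from compound 1 to compound 3 (within the scatter), which shows that swapping one side chain for methylcarbamoyl left the number in place. Compound 3, with its methylcarbamoyl, gives 50 nM, far lower than the acid. However, compound 3 also carries fluoro where compound 2 carries chloro, so only part of that gap can be expected to carry over to compound 4.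

The expected size of the change is a 5.3-fold lower number from compound 2 to compound 4 (0.73 log units; beyond the scatter), towards stronger inhibition. For compound 4 the estimated value in this assay is 120 nM, with an expected range from 40 nM to 400 nM.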

Compound 4, half-maximal inhibitory concentration: 40 nM
For compound 4 the middle estimate is 3.0-fold (0.48 log units) above the measured one; the measured number falls inside the stated range.
By their numbers in this assay, from the lowest: compounds 4, 1 and 3 (each within the scatter of the next); then compound 2.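

Changing carboxy to (2-hydroxyethyl)carbamoyl in this assay gives a 16-fold lower number from compound 2 to compound 4 (1.20 log units; beyond the scatter), the first step shown that isolates this change with the rest of the molecule held fixed. The rest of compound 2 is therefore compatible with a low number in this read-out: compound 4 keeps all of it and gives 40 nM, so the high number of the acid is tied to what sits on the carbonyl carbon. Why replacing hydroxy at this place has so large an effect is not explained by any measurement available here.

The compounds shown leave open whether the amide alone accounts for the step or whether the terminal hydroxy of the new chain adds to it; a plain carbamoyl or a (2-methoxyethyl)carbamoyl group at the same place would separate those two parts. Also open, going by these compounds, is how a longer chain, such as (3-hydroxypropyl)carbamoyl, or an amine in place of the hydroxy at the chain end would read in this assay.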